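Series notes: fluoro for methyl on compound 2

The source may hold more compounds than are shown below. What is called first, only, known or untested is meant among the compounds shown, and "the series" means these compounds.

Measured in a functional assay on A549 cells (Homo sapiens) for antiproliferative activity, read by MTT assay, with a stated time of 24 h; a higher number here means a weaker inhibitor, a lower number a stronger inhibitor:
- compound 1 `Cc1ccc(-c2nn(-c3ccccc3)cc2-c2nc3ccccc3n2S(=O)(=O)c2cc(C)ccc2C)cc1`: 270 nM
- compound 2 `Cc1ccc(-c2nn(-c3ccccc3)cc2-c2nc3ccccc3n2S(=O)(=O)c2ccc(Cl)cc2)cc1`: 3550 nM
- compound 3 `Cc1ccc(-c2nn(-c3ccccc3)cc2-c2nc3ccccc3n2S(=O)(=O)c2ccc(C(F)(F)F)cc2)cc1`: 1460 nM

Compound 2 gives the highest number of the three, making it the weakest inhibitor so far. Compound 4 `O=S(=O)(c1ccc(Cl)cc1)n1c(-c2cn(-c3ccccc3)nc2-c2ccc(F)cc2)nc2ccccc21` is not yet measured. Its difference from compound 2 is fluoro in place of methyl on an aromatic carbon, a change from 4-methylphenyl to 4-fluorophenyl.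

Among the measured compounds shown here, no measured step touches this group. All three concern the aryl group on the sulfonyl sulfur: a 13-fold higher number from compound 1 to compound 2 (1.12 log units; beyond the scatter), a 5.4-fold higher number from compound 1 to compound 3 (0.73 log units; beyond the scatter) and a 2.4-fold lower number from compound 2 to compound 3 (0.39 log units; beyond the scatter). For the measured compounds named here, the last is the closest precedent, as one small substituent replaces another on an aromatic carbon, yet it lies elsewhere in the molecule and offers only a loose guide. In this assay, as far as these compounds go, no step beyond the scatter is therefore expected, and the direction remains open. The expected outcome is a 1.2-fold lower number from compound 2 to compound 4 (0.07 log units; within the scatter).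

For compound 4 the estimated value is 3000 nM, with an expected range from 1200 nM to 7500 nM.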

Compound 4, half-maximal inhibitory concentration: 3170 nM
The estimate for compound 4 lay 1.1-fold (0.02 log units) below the measured number; the range from low to high includes it.
By their numbers in this assay, from the lowest: compound 1; then compound 3; then compounds 4 and 2 (each within the scatter of the next).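

In this assay, among the compounds shown here, the only measured change outside the sulfonyl aryl group, 4-fluorophenyl in place of 4-methylphenyl, gives a 1.1-fold lower number from compound 2 to compound 4 (0.05 log units; within the scatter) and so cannot be told apart from no change. This position therefore shows no response to fluoro for methyl in this one pair, whereas exchange of the sulfonyl aryl group gives a 13-fold higher number from compound 1 to compound 2 (1.12 log units; beyond the scatter) and stays beyond the scatter. No measured evidence bears on this result.

Still open, as far as these compounds go, is whether the same exchange stays within the scatter on the 2,5-dimethylphenyl sulfonyl background of compound 1, where the number is much lower. Also open, from the compounds shown here alone, is whether a group of another kind at this place, such as methoxy, an amine or a carboxylic acid, would move the number beyond the scatter.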